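Compound 4: chloro in place of trifluoromethyl

A few compounds are considered here, and "the series" means these few. Any claim that something is new, unique, unknown or untested is made for them only; others in the source may bear on it.

In an ADME assay on HeLa cells (Homo sapiens) for cytotoxicity (on this read-out higher numbers stand for lower toxicity in this test and lower numbers for higher toxicity in this test), compound 1 `C[C@@H](NC(=O)c1nc(-c2ccccn2)nc(O)c1O)C1CCCCC1` gives 3200 nM, compound 2 `Cc1ccnc(-c2nc(O)c(O)c(C(=O)N[C@H](C)C3CCCCC3)n2)c1` gives 2700 nM and compound 3 `C[C@@H](NC(=O)c1nc(-c2cc(C(F)(F)F)ccn2)nc(O)c1O)C1CCCCC1` gives 6000 nM. Compound 3 lies within the scatter of compound 1 and only modestly beyond it from compound 2, with a 2.2-fold higher number from compound 2 to compound 3 (0.35 log units; beyond the scatter).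

The next structure, compound 4 `C[C@@H](NC(=O)c1nc(-c2cc(Cl)ccn2)nc(O)c1O)C1CCCCC1`, has chloro in place of trifluoromethyl on an aromatic carbon, opposite the ring nitrogen: chloro in place of trifluoromethyl on an aromatic carbon.

Going by the values given here, no chloro compound has been measured, so the evidence comes from the other changes at this carbon. Two of them stay within the scatter, a 1.2-fold lower number from compound 1 to compound 2 (0.07 log units; within the scatter) and a 1.9-fold higher number from compound 1 to compound 3 (0.27 log units; within the scatter). The largest, a 2.2-fold higher number from compound 2 to compound 3 (0.35 log units; beyond the scatter), is small. A step beyond the scatter is therefore not expected in this assay, and the expected change is a 1.5-fold lower number from compound 3 to compound 4 (0.18 log units; within the scatter). The estimated value for compound 4 is 4000 nM, with an expected range from 2200 nM to 8000 nM.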

Compound 4, half-maximal cytotoxic concentration: 3000 nM
Beside the measured number, compound 4's estimate is 1.3-fold (0.12 log units) above it; the range from low to high includes it.
By their numbers in this assay, from the lowest: compounds 2, 4, 1 and 3 (each within the scatter of the next, the first and the last beyond it).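

In this assay, chloro on this carbon, opposite the ring nitrogen, stays within the scatter of all three earlier groups, with a 2.0-fold lower number from compound 3 to compound 4 (0.30 log units; within the scatter) against trifluoromethyl, a 1.1-fold higher number from compound 2 to compound 4 (0.05 log units; within the scatter) against methyl and a 1.1-fold lower number from compound 1 to compound 4 (0.03 log units; within the scatter) against hydrogen. Going by these compounds alone, exchanging 4 heavy atoms for 1 at this place therefore gives no step beyond the scatter, and the only such step at this carbon remains a 2.2-fold higher number from compound 2 to compound 3 (0.35 log units; beyond the scatter) between methyl and trifluoromethyl. No measured property in these notes bears on this result.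

The compounds shown leave open what an amine or a carboxylic acid on this carbon would do in this assay and whether either would give a step beyond the scatter. They also leave open whether these small steps would hold with a change elsewhere on the shared core.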